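The compounds below may be only part of what the source reports. "The series", "measured", "known", "first", "only" and "open" are said of these compounds alone.

Compound 1 `CN(Cc1ccccc1)C1CCc2ccsc2CC1` and compound 2 `CN(CCCc1ccccc1)C1CCc2ccsc2CC1` have different cores, and the difference between the two cores is not broken down here. In an assay on membranes from brain for displacement of a labelled ligand from Sigma non-opioid intracellular receptor 1 (Cavia porcellus), read by scintillation counting, with a stated time of 120 min (a higher number here means a weaker inhibitor, a lower number a stronger inhibitor), compound 1 gives 49 nM, while compound 2 gives 10 nM, the lowest of the three numbers. Compound 3 `CCN(Cc1ccccc1)C1CCc2ccsc2CC1` differs from compound 1 by methyl in place of hydrogen on a saturated chain carbon bound to an amine nitrogen; in this assay compound 3 gives 60 nM. The measured step is a 1.2-fold higher number from compound 1 to compound 3 (0.09 log units; within the scatter). Compound 4 `CCN(CCCc1ccccc1)C1CCc2ccsc2CC1` has not yet been tested. It differs from compound 2 by methyl in place of hydrogen on a saturated chain carbon bound to an amine nitrogen, the same change at the same place. Because the earlier step was a 1.2-fold higher number from compound 1 to compound 3 (0.09 log units; within the scatter), a similarly small step is expected here, a 1.2-fold higher number from compound 2 to compound 4 (0.08 log units; within the scatter). Compound 4 is therefore expected to give 12 nM, with a likely range from 5 nM to 28 nM.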

Compound 4, inhibition constant: 17 nM
Estimate against measurement, compound 4: 1.4-fold (0.15 log units) below; low and high end bracket the measured number.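

In this assay the new step is a 1.7-fold higher number from compound 2 to compound 4 (0.23 log units; within the scatter), so on this core, replacing the methyl on the amine nitrogen with ethyl leaves the number within the usual scatter. The same change gives a matching result on the second core: the same change on two cores in this assay, a 1.2-fold higher number (0.09 log units; within the scatter) from compound 1 to compound 3 and a 1.7-fold higher number (0.23 log units; within the scatter) from compound 2 to compound 4, 1.4-fold (0.14 log units) apart, within the scatter of two such steps. This shows that the change can be carried between these two cores without a step beyond the scatter, but it does not show that this would hold on any other core, and steps this small cannot show whether the change has any real effect at all.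

The compounds shown leave open how a longer chain, such as propyl or butyl, in place of the ethyl would read in this assay.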